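Replacing Methyl with Bromo in Compound 2

The source may hold more compounds than are shown below. What is called first, only, known or untested is meant among the compounds shown, and "the series" means these compounds.

In an ADME assay on Vero cells (Chlorocebus sabaeus) for cytotoxicity, read by resazurin assay, with a stated time of 72 h (a lower number here means a stronger inhibitor, a higher number a weaker inhibitor), compound 1 `Cc1ccc(C(=O)CCN2CCN(c3ccc(F)cc3)CC2)cc1` gives 55400 nM and compound 2 `Cc1ccc(C(=O)CCN2CCN(c3ccc(Cl)cc3)CC2)cc1` gives 184000 nM, the higher of the two numbers. Compound 3 `O=C(CCN1CCN(c2ccc(Cl)cc2)CC1)c1ccc(Br)cc1` has not yet been measured. It differs from compound 2 in one place: bromo in place of methyl on an aromatic carbon. Within the data shown here, the only measured step, a 3.3-fold higher number from compound 1 to compound 2 (0.52 log units; beyond the scatter), is modest and comes from chloro in place of fluoro on an aromatic carbon. That swap lies elsewhere in the molecule and involves different groups, so it gives the size of a plausible move but no direction for this one. The expected step, a 1.0-fold lower number from compound 2 to compound 3 (0.01 log units; within the scatter), is therefore none beyond the scatter in this assay, though a move of similar size either way remains possible. For compound 3 the estimated value is 180000 nM, with an expected range of 60000 nM to 450000 nM.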

Compound 3, half-maximal inhibitory concentration: 52100 nM
Compound 3: middle estimate off by 3.5-fold (0.54 log units), on the high side; the whole stated range lies above it.
By their numbers in this assay, from the lowest: compounds 3 and 1 (each within the scatter of the next); then compound 2.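

In this assay, the change from 4-methylphenyl to 4-bromophenyl gives a 3.5-fold lower number from compound 2 to compound 3 (0.55 log units; beyond the scatter), so the group on this aromatic carbon, para to a large group, affects the reading even though only one heavy atom is exchanged and no ring, hydrogen-bond donor, hydrogen-bond acceptor or net charge enters or leaves. The earlier step, a 3.3-fold higher number from compound 1 to compound 2 (0.52 log units; beyond the scatter), came from a change elsewhere in the molecule and raised the number, whereas this one lowers it. Nothing measured here explains the fall in the number.

From the compounds shown here alone, a single pair cannot separate the effect of gaining bromo from that of losing methyl, and how a hydrogen, methoxy or trifluoromethyl on this carbon would read remains open. Going by these compounds, it is also open whether the same swap gives a similar step when fluoro stands in place of chloro, as in compound 1.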